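Cytotoxicity notes: changing the aryl group of compound 2

The compounds below may be only part of what the source reports. "The series", "measured", "known", "first", "only" and "open" are said of these compounds alone.

Of the compounds shown here, two have been read so far in an ADME assay on Vero cells (Chlorocebus sabaeus) for cytotoxicity, read by MTT assay, with a stated time of 96 h; on this read-out lower numbers stand for higher toxicity in this test and higher numbers for lower toxicity in this test. Compound 1 `COc1ccc(-c2nc3cc(/C(C)=N/NC(N)=S)ccc3[nH]2)c(OC)c1` returned > 100000 nM, which is a limit of the assay and not a number. Among the compounds with values here, compound 2 `C/C(=N\NC(N)=S)c1ccc2c(c1)nc(-c1ccccc1)n2C1CCCCC1` gave 20000 nM, the only actual number, so its standing rests on this single reading.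

Next is compound 3 `COc1ccc(-c2nc3cc(/C(C)=N/NC(N)=S)ccc3n2C2CCCCC2)c(OC)c1`. It keeps the cyclohexyl group of compound 2 and carries 2,4-dimethoxyphenyl in place of phenyl on an aromatic carbon, between two ring nitrogen atoms: 2,4-dimethoxyphenyl in place of phenyl on an aromatic carbon.

Within the data shown here, no step between measured compounds is available to size this change. Among the measured compounds shown here, the only guide is compound 1, which also carries 2,4-dimethoxyphenyl and whose > 100000 nM is a limit. A small move toward lower toxicity in this assay is therefore expected, estimated as a 1.8-fold higher number from compound 2 to compound 3 (0.24 log units; within the scatter), which would stay within the usual scatter. For compound 3 the estimated half-maximal cytotoxic concentration is 35000 nM, with an expected range of 12000 nM to 100000 nM.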

Compound 3, half-maximal cytotoxic concentration: 20000 nM
Estimate against measurement, compound 3: 1.8-fold (0.24 log units) above, within the range that was stated.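

In this assay, the change at this position, on an aromatic carbon between two ring nitrogen atoms, gives no change at the digits printed from compound 2 to compound 3 (within the scatter), so with cyclohexyl held in place the read-out does not separate 2,4-dimethoxyphenyl from phenyl. Within the data shown here, the other new step reads a different place in the molecule, with 2,4-dimethoxyphenyl held constant and cyclohexyl in place of hydrogen on an aromatic nitrogen, and it gives an at least 5.0-fold lower number from compound 1 to compound 3 (0.69 log units; beyond the scatter), the first step that lies beyond the scatter. The true size of that step stays open as a bound only, because the value of compound 1 is a limit of the assay and not a number: the limit of > 100000 nM in this assay, at which 1 of the 3 values shown sits.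

The compounds shown leave open how far the cyclohexyl step extends past that bound, and whether a methyl group or a longer alkyl chain on the aromatic nitrogen would give a number close to that of compound 3. They also leave open whether the aromatic carbon position stays equally silent with a phenyl ring carrying an amine or a carboxylic acid.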